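The compounds below may be only part of what the source reports. "The series", "measured", "known", "first", "only" and "open" are said of these compounds alone.

Measured compounds:
Compound 1, `CN1CCN(c2ccc(C3=NNC(c4ccc(N(C)C)cc4)C3)cc2)CC1`, gives 11.4% in a functional assay on MDA-MB-231 cells (Homo sapiens) for inhibition, read by sulforhodamine B assay, tested at 10 uM; a lower number here means less inhibition, a higher number more inhibition at the concentration tested (going by the name of the read-out).
Compound 2, `CN(C)c1ccc(C2CC(c3ccc(-n4ccnc4)cc3)=NN2)cc1`, gives 7.6% in this assay.

Compound 1 stands highest of the two numbers, but its nearest neighbour is compound 2, and the step of a number 3.8 percentage points lower from compound 1 to compound 2 (within the scatter) lies within the scatter, so the two measured compounds cannot be told apart in this assay.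

Compound 3, `CC(=O)N1N=C(c2ccc(N3CCN(C)CC3)cc2)CC1c1ccc(N(C)C)cc1`, is not yet measured. It differs from compound 1 by acetyl in place of hydrogen on an amine nitrogen in a ring. The only measured step, from compound 1 to compound 2, swaps one aromatic substituent for another and leaves the ring nitrogen untouched; it was small, as shown by a number 3.8 percentage points lower from compound 1 to compound 2 (within the scatter), and it does not bear on an acetyl in place of hydrogen on an amine nitrogen in a ring. Within the data shown here, no measured pair in this set changes that nitrogen, so there is no basis for expecting a step beyond the scatter in this assay in either direction.

Compound 3 is therefore expected to give about 12% in this assay, with a range from 0% to 30%. The expected step of a number 0.6 percentage points higher from compound 1 to compound 3 (within the scatter) is estimated to stay within the scatter.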

Compound 3, a percentage reported as inhibition, at one concentration (the size of the read-out at that concentration, not a potency): -1%
Beside the measured number, compound 3's estimate is 13 percentage points above it, outside the stated range (below it).
By their numbers in this assay, from the lowest: compounds 3, 2 and 1 (each within the scatter of the next, the first and the last beyond it).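

Acetyl in place of hydrogen on an amine nitrogen in a ring is the first change at this position that can be read in this assay, and it gives a number 12.4 percentage points lower from compound 1 to compound 3 (beyond the scatter). The earlier step, an exchange of aromatic substituents far from this nitrogen in the structure, stayed small at a number 3.8 percentage points lower from compound 1 to compound 2 (within the scatter), so this nitrogen is the only place in the set where a single change has moved the number beyond the scatter, with compound 3 at -1% and no measurable inhibition left at the concentration tested. Nothing available gives a reason for this step, so the result stands as an observation only.

The compounds shown leave open whether the loss belongs to acetyl itself or would follow any group on this nitrogen, such as a formyl group, a longer acyl chain like propanoyl, or a simple methyl. They also leave open whether the same step would appear with 1H-imidazol-1-yl in place of 4-methylpiperazin-1-yl on the aromatic carbon, and, since each number comes from a single concentration, how any of these compounds would compare in potency.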